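Swapping Cyclohexyl for Benzyl on a Fused Ring Nitrogen

The compounds below may be only part of what the source reports. "The series", "measured", "known", "first", "only" and "open" are said of these compounds alone.

Measured compounds:
Compound 1, `O=Cc1ccc(-c2cn3ccnc3c(-c3ccc4ncn(Cc5ccccc5)c4c3)n2)cc1`, gives 47.8%.
Compound 2, `c1ccc(Cn2cnc3ccc(-c4nc(-c5cccc6ccccc56)cn5ccnc45)cc32)cc1`, gives 29.2%.
Compound 3, `c1cn2cc(-c3ccc4c(c3)ncn4C3CCCCC3)nc(-c3ccc4ncn(C5CCCCC5)c4c3)c2n1`, gives 19.1%.

All three were tested in a functional assay on MCF7 cells (Homo sapiens) for inhibition, read by sulforhodamine B assay, with a stated time of 48 h, tested at 10 uM; on this read-out higher numbers stand for more inhibition at the one concentration tested (going by the name of the read-out) and lower numbers for less inhibition. Compound 3 stands lowest of the three numbers; compound 2 lies nearest to it, and compound 1 furthest, both beyond the scatter. Going by the values given here, the one measured step, a number 18.6 percentage points lower from compound 1 to compound 2 (beyond the scatter), concerns a change on an aromatic carbon and so tells nothing directly about the nitrogen substituent considered here.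

Compound 4, `c1ccc(Cn2cnc3ccc(-c4nc(-c5ccc6c(c5)ncn6C5CCCCC5)cn5ccnc45)cc32)cc1`, is not yet measured in this assay. It differs from compound 3 by benzyl in place of cyclohexyl on an aromatic nitrogen. Among the compounds with values here, no measured pair isolates this change, so the expectation rests only on the observation that compounds 1 and 2, which both carry benzyl on such a nitrogen, stand above compound 3, though they differ from it elsewhere as well. A modest rise is therefore expected, as the step of a number 8.9 percentage points higher from compound 3 to compound 4 (within the scatter). Compound 4 is thus estimated at 28%, within a range from 12% to 45%.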

Compound 4, a percentage reported as inhibition, at one concentration (the size of the read-out at that concentration, not a potency): 98%
For compound 4 the middle estimate is 70 percentage points below the measured one; measured number above the stated range.
By their numbers in this assay, from the lowest: compound 3; then compound 2; then compound 1; then compound 4.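

In this assay, going by these compounds alone, the swap of cyclohexyl for benzyl gives a number 78.9 percentage points higher from compound 3 to compound 4 (beyond the scatter), the first direct reading of this position, and it shows that the group on this aromatic nitrogen of the five-membered ring can strongly change the inhibition seen at the one concentration tested. The counts under comparison give little warning of so large a step: benzyl has 7 heavy atoms and cyclohexyl 6, both consist of carbon only with one six-membered ring, and neither has hydrogen-bond donors, hydrogen-bond acceptors or a net charge, so what separates them here is an aromatic ring in place of a non-aromatic one, together with one more carbon. No measurement available here explains why this swap has such a large effect.

The compounds shown do not separate those two differences, which a phenyl group or a cyclohexylmethyl group on the same nitrogen could help to tease apart. On these data alone, it also remains open how a group of another kind would behave at this position, such as a longer chain ending in an amine, and whether compound 4 would keep its lead over compound 3 across a range of concentrations.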